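Replacing a bromophenyl amide with a methylphenyl amide

The compounds below may be only part of what the source reports. "The series", "measured", "known", "first", "only" and "open" are said of these compounds alone.

Three amides on a shared core have been measured in a functional assay on HCT-116 cells (Homo sapiens) for antiproliferative activity, read by MTT assay, with a stated time of 48 h; on this read-out higher numbers stand for weaker inhibition and lower numbers for stronger inhibition. Compound 1 `O=C(Nc1cccc(/C=C/C(=O)c2nc3ccccc3[nH]2)c1)c1ccccc1` gives 2440 nM. Compound 2 `O=C(/C=C/c1cccc(NC(=O)c2ccccc2Cl)c1)c1nc2ccccc2[nH]1` gives 1280 nM, and compound 3 `O=C(Nc1cccc(/C=C/C(=O)c2nc3ccccc3[nH]2)c1)c1cccc(Br)c1` gives 1560 nM. On these numbers compound 3 holds the second highest value of the three; its nearest neighbour is compound 2, with a 1.2-fold higher number from compound 2 to compound 3 (0.09 log units; within the scatter), and its furthest is compound 1, with a 1.6-fold lower number from compound 1 to compound 3 (0.19 log units; within the scatter). Neither gap rises above the scatter of the method.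

Compound 4 `Cc1ccccc1C(=O)Nc1cccc(/C=C/C(=O)c2nc3ccccc3[nH]2)c1` has not yet been measured. It differs from compound 3 in one place: 2-methylphenyl in place of 3-bromophenyl on a carbonyl carbon. Going by the values given here, three measured steps bear on this change. Introducing a halogen on the ring attached to the carbonyl gave a 1.9-fold lower number from compound 1 to compound 2 (0.28 log units; within the scatter) and a 1.6-fold lower number from compound 1 to compound 3 (0.19 log units; within the scatter), and exchanging one halogenated ring for the other gave a 1.2-fold higher number from compound 2 to compound 3 (0.09 log units; within the scatter); every one of these lies within the scatter. On this record compound 4 is expected to show no step beyond the scatter in this assay, a 1.0-fold lower number from compound 3 to compound 4 (0.02 log units; within the scatter). The estimate for compound 4 is accordingly 1500 nM, with a range from 700 nM to 3200 nM.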

Compound 4, half-maximal inhibitory concentration: 1870 nM
Beside the measured number, compound 4's estimate is 1.2-fold (0.10 log units) below it, within the range that was stated.
By their numbers in this assay, from the lowest: compounds 2, 3, 4 and 1 (each within the scatter of the next).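

In this assay, the record now reaches beyond halogens to a carbon substituent on the ring attached to the carbonyl: 2-methylphenyl in place of 3-bromophenyl gives a 1.2-fold higher number from compound 3 to compound 4 (0.08 log units; within the scatter), methyl in place of chloro on an aromatic carbon gives a 1.5-fold higher number from compound 2 to compound 4 (0.16 log units; within the scatter), and methyl in place of hydrogen gives a 1.3-fold lower number from compound 1 to compound 4 (0.12 log units; within the scatter). The earlier compounds shown here had tested only hydrogen, chloro and bromo, so the new steps show that a methyl-bearing ring also stays within the scatter of all three, and that no change made on this ring so far separates any two of the four compounds. No measured information bears on why these steps are so small.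

The compounds shown leave open whether any group on this ring can move the number beyond the scatter in this assay, for instance an amine, a carboxylic acid or a longer alkyl chain. They also leave open whether a ring carrying two such groups would behave as these singly substituted rings do.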